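A few compounds are considered here, and "the series" means these few. Any claim that something is new, unique, unknown or untested is made for them only; others in the source may bear on it.

Measured compounds:
Compound 1 `N#Cc1cc(C(=O)N2CC=CC2)cc(Cl)c1O` — in an assay on isolated protein for inhibition of solute carrier family 22 member 12 (Homo sapiens), tested at 3 uM (a higher number here means more inhibition at the concentration tested (going by the name of the read-out), a lower number less inhibition), compound 1 gives 66%
Compound 2 `CCCc1cc(C(=O)N2CC=CC2)cc(C#N)c1O` — compound 2 gives 70%
Compound 3 `CC(C)(C)c1cc(C(=O)N2CC=CC2)cc(C#N)c1O` — compound 3 gives 92%

Compound 3 holds the highest of the three numbers: the nearest is compound 2, with a number 22 percentage points higher from compound 2 to compound 3 (beyond the scatter) separating them, and the furthest is compound 1, with a number 26 percentage points higher from compound 1 to compound 3 (beyond the scatter). The remaining step, a number 4 percentage points higher from compound 1 to compound 2 (within the scatter), lies within the scatter.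

Compound 4 `CC(C)(C)c1cc(C(=O)N2CCC2)cc(C#N)c1O` has not yet been measured. It differs from compound 3 in one place: a group of 4 heavy atoms (3 carbon, 1 nitrogen; one four-membered non-aromatic ring with 1 hetero atom) in place of a group of 5 heavy atoms (4 carbon, 1 nitrogen; one five-membered non-aromatic ring with 1 hetero atom), on a carbonyl carbon. None of the three measured steps bears on this change; each of them alters the group on an aromatic carbon, while the amide end of the shared core is identical across compounds 1, 2 and 3. No information on this kind of change is therefore available from the measured set.

With nothing to guide the direction, compound 4 is expected to stay close to compound 3, and the estimated step is a number 12 percentage points lower from compound 3 to compound 4 (beyond the scatter), with a wide range. Compound 4 is estimated at 80%, between 55% and 95%.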

Compound 4, a percentage reported as inhibition, at one concentration (the size of the read-out at that concentration, not a potency): 71%
Compound 4: middle estimate off by 9 percentage points, on the high side; the range from low to high includes it.
By their numbers in this assay, from the lowest: compounds 1, 2 and 4 (each within the scatter of the next); then compound 3.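

Among these compounds, the earlier compounds varied only the group on an aromatic carbon, so this is the only view of the group on the carbonyl carbon, and in this assay that group also moves the number: azetidin-1-yl in place of the five-membered ring gives a number 21 percentage points lower from compound 3 to compound 4 (beyond the scatter). Compound 4 keeps the tert-butyl group, so the high number of compound 3 does not rest on tert-butyl alone. No measurement at hand explains this step.

The change both shrinks the ring and removes its double bond, and the compounds shown leave open which of the two matters; a pyrrolidin-1-yl or piperidin-1-yl group on the carbonyl carbon would help to separate them. Also open, going by these compounds, is whether the step would look the same with propyl or chloro in place of tert-butyl.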